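Series notes: 2-methoxyphenyl in place of cyclohexylmethyl

This account rests on a few compounds, and the source may have more. Where it says the series, first, only, none or still open, it means among the compounds named here.

Three measured compounds share one core and differ only in the group carried on its far end. Compound 1 `O=C(O)c1ccccc1-c1ccc(CCc2ncc(C3CCCCC3)[nH]2)cc1` gives 375 nM in an in vitro functional assay on cells for agonist activity at Bombesin receptor subtype-3 (Homo sapiens), read by luminescence and calcium flux; on this read-out lower numbers stand for an effect already at smaller amounts and higher numbers for an effect only at larger amounts of compound. Compound 2 `N#Cc1cccc(Cc2cnc(CCc3ccc(-c4ccccc4C(=O)O)cc3)[nH]2)c1` gives 812 nM in this assay, and compound 3 `O=C(O)c1ccccc1-c1ccc(CCc2ncc(CCC3CCCCC3)[nH]2)cc1` gives 642 nM in this assay. Compound 3 thus stands second highest of the three numbers; its nearest neighbour is compound 2 and its furthest is compound 1, both within the scatter, as a 1.3-fold lower number from compound 2 to compound 3 (0.10 log units; within the scatter) and a 1.7-fold higher number from compound 1 to compound 3 (0.23 log units; within the scatter) show. Among the compounds with values here, the only step beyond the scatter in the set is a 2.2-fold higher number from compound 1 to compound 2 (0.34 log units; beyond the scatter).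

Compound 4 `COc1ccccc1Cc1cnc(CCc2ccc(-c3ccccc3C(=O)O)cc2)[nH]1` differs from compound 3 by 2-methoxyphenyl in place of cyclohexylmethyl on a saturated chain carbon bound to an aromatic carbon. The step that bears most directly on it is a 1.3-fold lower number from compound 2 to compound 3 (0.10 log units; within the scatter), which exchanged an aromatic ring for cyclohexylmethyl at the same place and stayed within the scatter; a 2.2-fold higher number from compound 1 to compound 2 (0.34 log units; beyond the scatter) is the modest move in the other direction, from a saturated to an aromatic group. Within the data shown here, no measured compound carries a methoxy group, so its own contribution is unknown. For compound 4 the expected step is therefore a 1.2-fold higher number from compound 3 to compound 4 (0.10 log units; within the scatter), nothing beyond the scatter. Compound 4 is accordingly estimated at 800 nM in this assay, within a range from 400 nM to 1600 nM.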

Compound 4, half-maximal effective concentration: 1720 nM
Compound 4: the middle estimate sits 2.2-fold (0.33 log units) below what was measured; the measured number lies above the stated range.
By their numbers in this assay, from the lowest: compounds 1, 3 and 2 (each within the scatter of the next, the first and the last beyond it); then compound 4.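

In this assay, within the data shown here, this position proves less tolerant than the earlier compounds suggested: exchanging the 3-cyanophenyl of compound 2 for cyclohexylmethyl stayed within the scatter, whereas 2-methoxyphenyl moves beyond it, both from the saturated group (a 2.7-fold higher number from compound 3 to compound 4 (0.43 log units; beyond the scatter)) and from the other aromatic group (a 2.1-fold higher number from compound 2 to compound 4 (0.33 log units; beyond the scatter)). An aromatic ring on the saturated chain carbon therefore does not fix the outcome, since the two substituted phenyl groups give numbers that differ beyond the scatter. With the largest step in the set so far (a 4.6-fold higher number from compound 1 to compound 4 (0.66 log units; beyond the scatter)), compound 4 now has the highest number, and its steps to all three other compounds lie beyond the scatter.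

Nothing available explains the rise in the number on entering 2-methoxyphenyl.

The compounds shown do not separate the methoxy group itself from where it sits on the ring, and a plain phenyl and a 3-methoxyphenyl at this place would address those two points. On these data alone, whether a 2-cyanophenyl behaves like the 2-methoxyphenyl or like the 3-cyanophenyl also remains open.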